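Removing a Methyl from the Piperazine Nitrogen

A few compounds are considered here, and "the series" means these few. Any claim that something is new, unique, unknown or untested is made for them only; others in the source may bear on it.

Three esters of the same bicyclic alcohol have been tested in an ADME assay on MDCK cells (Canis lupus familiaris) for cytotoxicity, read by MTT assay, with a stated time of 48 h; on this read-out lower numbers stand for higher toxicity in this test and higher numbers for lower toxicity in this test. Compound 1 `CCOC(=O)N1CCN(CCC(=O)O[C@@H]2C[C@@H]3CC[C@@]2(C)C3(C)C)CC1` gives 150000 nM in this assay. Compound 2 `CCN1CCN(CCC(=O)O[C@@H]2C[C@@H]3CC[C@@]2(C)C3(C)C)CC1` gives 105000 nM. Compound 3 `CN1CCN(CC(=O)O[C@@H]2C[C@@H]3CC[C@@]2(C)C3(C)C)CC1` gives 103000 nM. Among the measured compounds shown here, the one single-point step among them, a 1.4-fold lower number from compound 1 to compound 2 (0.15 log units; within the scatter), stays within the scatter, and the numbers for compound 3 and compound 2 are also indistinguishable within the scatter, as are those for compound 3 and compound 1; compound 3 therefore stands alongside the other two rather than apart from them.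

Compound 4 `CC1(C)[C@H]2CC[C@]1(C)[C@H](OC(=O)CN1CCNCC1)C2` has not yet been measured. Its change from compound 3 is hydrogen in place of methyl on an amine nitrogen in a ring. For the measured compounds named here, the only measured step that touches the same nitrogen is the replacement of ethoxycarbonyl by ethyl, a 1.4-fold lower number from compound 1 to compound 2 (0.15 log units; within the scatter), which did not move the number beyond the scatter. Going by the values given here, no measured pair shows a methyl giving way to a hydrogen, so the expectation rests on that single neighbouring step. Accordingly compound 4 is expected to show a 1.0-fold lower number from compound 3 to compound 4 (0.01 log units; within the scatter), a change not beyond the scatter. Compound 4 is estimated at 100000 nM, with a range from 50000 nM to 200000 nM.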

Compound 4, half-maximal cytotoxic concentration: 51600 nM
For compound 4 the middle estimate is 1.9-fold (0.29 log units) above the measured one; the range from low to high includes it.
By their numbers in this assay, from the lowest: compounds 4, 3, 2 and 1 (each within the scatter of the next, the first and the last beyond it).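

Replacing 4-methylpiperazin-1-yl with piperazin-1-yl gives a 2.0-fold lower number from compound 3 to compound 4 (0.30 log units; within the scatter) in this assay. Among the compounds shown here, this is the first measured case in which this amine nitrogen in a ring carries only a hydrogen, and even removing the carbon group entirely does not take the number beyond the usual scatter of repeated measurements. Nothing at hand points to a cause for the size of this step.

The compounds shown leave open whether a bulkier group on this nitrogen, such as benzyl or acetyl, would move the number beyond the scatter. They also leave open whether hydrogen in place of ethyl on the same nitrogen would give a similar step when the ester carries the chain of compound 2.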